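The source may hold more compounds than are shown below. What is called first, only, known or untested is meant among the compounds shown, and "the series" means these compounds.

Measured compounds in a functional assay on HepG2 cells (Homo sapiens) for antiproliferative activity, read by MTT assay, with a stated time of 72 h; on this read-out higher numbers stand for weaker inhibition and lower numbers for stronger inhibition:
compound 1 `NC1=NC2(CCOCC2)N(OCCCOc2ccccc2Cl)C(N)=N1`: 1750 nM
compound 2 `NC1=NC2(CCSCC2)N(OCCCOc2cccc(Cl)c2Cl)C(N)=N1`: 50 nM
compound 3 `NC1=NC2(CCSCC2)N(OCCCOc2cc(Cl)c(Cl)cc2Cl)C(N)=N1`: > 100000 nM, a limit of the assay the limit of > 100000 nM in this assay, at which 1 of the 3 values shown sits.

Compound 1 stands highest of the two numbers in this assay; its nearest neighbour is compound 2, a lower number beyond the scatter.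

Compound 4 `NC1=NC2(CCOCC2)N(OCCCOc2ccccc2Br)C(N)=N1` differs from compound 1 by bromo in place of chloro on an aromatic carbon. Going by the values given here, the single measured step, an at least 2000-fold higher number from compound 2 to compound 3 (3.30 log units; beyond the scatter), concerns the chlorine pattern on the phenyl ring, not the exchange of one halogen for another, so it bears only loosely on this change. Among the compounds with values here, no step here tests bromo against chloro. A step within the scatter is therefore expected, a 1.2-fold lower number from compound 1 to compound 4 (0.07 log units; within the scatter). Compound 4 is estimated at 1500 nM, with a range from 500 nM to 5000 nM.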

Compound 4, half-maximal inhibitory concentration: 860 nM
The estimate for compound 4 lay 1.7-fold (0.24 log units) above the measured number, within the range that was stated.
By their numbers in this assay, from the lowest: compound 2; then compound 4; then compound 1. At a limit, above all of these: compound 3.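

In this assay, bromo in place of chloro gives a 2.0-fold lower number from compound 1 to compound 4 (0.31 log units; beyond the scatter) and thus shows that the halogen itself, ortho to a large group, shifts the read-out modestly. The earlier compounds shown here compared only chlorine patterns on the phenyl ring, not one halogen against another. Nothing measured among these compounds explains the step.

Going by these compounds, whether fluoro, methoxy or nitrile at this place would continue the step remains open. Also open, on these data alone, is whether bromo in place of chloro gives a similar step on the core of compound 2.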